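Working notes: aryl to benzyl change on the ring nitrogen

The compounds below may be only part of what the source reports. "The series", "measured", "known", "first", "only" and "open" are said of these compounds alone.

The two measured compounds share one core and differ only in the group on an aromatic nitrogen: compound 1 `Cc1cccc(-n2cc(CNC(=O)c3cccc4c3cnn4C(C)C)nn2)c1` bears 3-methylphenyl, compound 2 `Cc1ccccc1-n1cc(CNC(=O)c2cccc3c2cnn3C(C)C)nn1` bears 2-methylphenyl. In a functional assay on MCF7 cells (Homo sapiens) for inhibition, read by MTT assay, with a stated time of 72 h (a lower number here means a stronger inhibitor, a higher number a weaker inhibitor), compound 1 gives only a limit of > 40000 nM. In this assay compound 2 likewise gives only a limit of > 40000 nM. The step that the two limits leave unreadable from compound 1 to compound 2 therefore cannot be read, and compound 2 stands at the limit of > 40000 nM in this assay, at which 2 of the 2 values shown sit, with no number of its own.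

Compound 3 `COc1ccc(Cn2cc(CNC(=O)c3cccc4c3cnn4C(C)C)nn2)cc1` differs from compound 2 by 4-methoxybenzyl in place of 2-methylphenyl on an aromatic nitrogen. Among the measured compounds shown here, the single measured step concerns a different change and is itself unreadable, so the measured compounds give neither a size nor a direction for this change in this assay. With both measured compounds at the limit, compound 3 is expected to show a step of a number no higher from compound 2 to compound 3 (the limit leaves the size open) from compound 2, not beyond the scatter. The estimate for compound 3 in this assay is 40000 nM, within 10000 nM to 100000 nM, with a strong chance that only a limit is reported again.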

Compound 3, half-maximal inhibitory concentration: > 40000 nM
Compound 3: a limit, no number (the forecaster's own chance of this, stated with the estimate: 70%); the middle value sits exactly at the limit.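

In this assay compound 3 gives only a limit, so the steps to compound 3 from compound 1 and from compound 2 cannot be read: the limit of > 40000 nM in this assay, at which 3 of the 3 values shown sit.

The compounds shown leave open whether 3-methylphenyl, 2-methylphenyl and 4-methoxybenzyl on the aromatic nitrogen differ at all in this assay, and in which direction any difference would run.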